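Thioamide to five-membered ring: compound 3 to compound 4

This account rests on a few compounds, and the source may have more. Where it says the series, first, only, none or still open, it means among the compounds named here.

Values in an ADME assay on RAW264.7 cells (Mus musculus) for cytotoxicity, read by MTT assay, with a stated time of 48 h; on this read-out lower numbers stand for stronger inhibition and higher numbers for weaker inhibition:
- compound 1 `CC(C)(Oc1ccc(Cl)cc1)C(=O)NCCOC(=S)Nc1ccc(F)cc1`: > 800000 nM
- compound 2 `Cc1ccc(NC(=S)OCCNC(=O)c2cccnc2)cc1`: > 800000 nM
- compound 3 `CC(C)(Oc1ccc(Cl)cc1)C(=O)Oc1ccc(C(N)=S)cc1`: > 800000 nM

Compound 3 stands at > 800000 nM in this assay, and this is a limit, not a number. Going by the values given here, the series so far shows only (the limit of > 800000 nM in this assay, at which 3 of the 3 values shown sit). The change to compound 4 `CC(C)(Oc1ccc(Cl)cc1)C(=O)Oc1ccc(-c2cc(=S)ss2)cc1` is a group of 6 heavy atoms (3 carbon, 3 sulfur; one five-membered aromatic ring with 2 hetero atoms) in place of a group of 3 heavy atoms (1 carbon, 1 nitrogen, 1 sulfur; no ring), on an aromatic carbon, on an aromatic carbon of a six-membered aromatic ring of carbon only, para to a large group. Among the compounds with values here, no measured pair gives a step size, so the expectation rests on the limit of > 800000 nM in this assay, at which 3 of the 3 values shown sit: a modest move toward lower numbers in this assay, or none beyond the scatter. The expected change is an at least 1.6-fold lower number from compound 3 to compound 4 (0.20 log units; that floor lies within the scatter). The estimate for compound 4 is 500000 nM, with an expected range from 100000 nM to 800000 nM.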

Compound 4, half-maximal inhibitory concentration: > 800000 nM
Compound 4: only a limit was reported; the forecaster's own chance of this, stated with the estimate: 55%; at least 1.6-fold (0.20 log units) between middle value and limit.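

Compound 3 and compound 4 both stand only as limits, so no step can be read between them. The compounds shown leave open whether the five-membered aromatic ring changes the read-out at all: the limit of > 800000 nM in this assay, at which 4 of the 4 values shown sit.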